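A few compounds are considered here, and "the series" means these few. Any claim that something is new, unique, unknown or untested is made for them only; others in the source may bear on it.

Compound 3 `CCn1c(/C=C2\SC(=O)N(CC(=O)N3CCOCC3)C2=O)nc2ccccc21` is assessed in a functional assay on DU-145 cells (Homo sapiens) for inhibition, read by MTT assay, with a stated time of 48 h; a lower number here means a stronger inhibitor, a higher number a weaker inhibitor. In this assay compound 3 reaches only the limit > 50000 nM, not a number. Its neighbour compound 2 `CC(C)n1c(/C=C2\SC(=O)N(CC(=O)N3CCOCC3)C2=O)nc2ccccc21` likewise sits at the limit > 50000 nM in this assay. The step that the two limits leave unreadable from compound 2 to compound 3 is therefore unreadable. Compound 1 `Cn1c(/C=C2\SC(=O)N(CC(=O)Nc3cc(C(C)(C)C)on3)C2=O)nc2ccccc21` carries the amide of compound 4 but a methyl on the aromatic nitrogen. In this assay, within the data shown here, compound 1 gives 31400 nM, the one number among the three, against (the limit of > 50000 nM in this assay, at which 2 of the 3 values shown sit). Compound 4 `CCn1c(/C=C2\SC(=O)N(CC(=O)Nc3cc(C(C)(C)C)on3)C2=O)nc2ccccc21` differs from compound 3 by (5-(tert-butyl)-1,2-oxazol-3-yl)amino in place of morpholin-4-yl on a carbonyl carbon. No measured step covers this amide change, and the only listed step is unreadable, so the expectation leans on compound 1 alone. Compound 4 is therefore expected at 35000 nM, from 15000 nM to 80000 nM. That is an estimated step of an at least 1.4-fold lower number from compound 3 to compound 4 (0.15 log units; that floor lies within the scatter), toward a readable number.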

Compound 4, half-maximal inhibitory concentration: > 50000 nM
Compound 4: a limit, no number; the forecaster's own chance of this, stated with the estimate: 40%; at least 1.4-fold (0.15 log units) between middle value and limit.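

With the (5-(tert-butyl)-1,2-oxazol-3-yl)amino group held in place on the carbonyl carbon, methyl in place of hydrogen on a saturated chain carbon bound to an aromatic nitrogen gives an at least 1.5-fold higher number from compound 1 to compound 4 (0.20 log units; that floor lies within the scatter). The exchange of morpholin-4-yl for that group on the carbonyl carbon thus shows no readable gain in this assay, and the steps between two limits cannot be read. Only compound 1 now stands apart from the shared limit: the limit of > 50000 nM in this assay, at which 3 of the 4 values shown sit.

Still open, going by these compounds, is whether a benzyl group on the aromatic nitrogen, or a carboxylic acid in place of the tert-butyl, would give a readable number in this assay.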